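Compound 4: Furan-2-yl in Place of Pyridin-3-yl

The compounds below may be only part of what the source reports. "The series", "measured", "known", "first", "only" and "open" are said of these compounds alone.

Measured so far in a physicochemical assay for solubility, in phosphate buffer, at pH 6.8 (on this read-out lower numbers stand for lower solubility and higher numbers for higher solubility), are these compounds:
- compound 1 `CCn1c(NC(C)C)nc2c(-c3cncnc3)csc2c1=O` gives 18 ug/mL
- compound 2 `CCn1c(NC(C)C)nc2c(-c3cccnc3)csc2c1=O` gives 5.8 ug/mL
- compound 3 `CCn1c(NC(C)C)nc2c(C3CCCN(C(C)=O)C3)csc2c1=O` gives 230 ug/mL

Compound 2 holds the lowest of the three numbers. Compound 4 `CCn1c(NC(C)C)nc2c(-c3ccco3)csc2c1=O` has furan-2-yl in place of pyridin-3-yl on an aromatic carbon of the shared core. Going by the values given here, one measured step bears on this place, and it is modest: a 3.1-fold lower number from compound 1 to compound 2 (0.49 log units; beyond the scatter) with pyridin-3-yl in place of pyrimidin-5-yl. Among the compounds with values here, it is the only guide, so a similarly modest move towards lower numbers is expected. The estimated change is a 2.3-fold lower number from compound 2 to compound 4 (0.37 log units; beyond the scatter) in this assay and this rests on a single step. Compound 4 is expected at 2.5 ug/mL within an estimated range of 0.8 ug/mL to 8 ug/mL in this read-out.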

Compound 4, solubility: 0.1 ug/mL
The estimate for compound 4 lay 25-fold (1.40 log units) above the measured number, and the stated range ends above it.
By their numbers in this assay, from the lowest: compound 4; then compound 2; then compound 1; then compound 3.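

Swapping pyridin-3-yl for furan-2-yl on this aromatic carbon gives a 58-fold lower number from compound 2 to compound 4 (1.76 log units; beyond the scatter) in this assay and, with furan-2-yl in place of pyrimidin-5-yl, a 180-fold lower number from compound 1 to compound 4 (2.26 log units; beyond the scatter) in the same read-out. Both steps are large, so this position can move the number much further than the modest step between the two six-membered aromatic rings showed. Nothing at hand explains the size of these steps. From the compounds shown here alone, whether the drop is particular to furan-2-yl, or would also follow with thiophen-2-yl, remains open. So does the outcome with a morpholine at this place.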